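The source may hold more compounds than are shown below. What is called first, only, known or untested is meant among the compounds shown, and "the series" means these compounds.

Measured so far in a functional assay on HeLa cells (Homo sapiens) for antiproliferative activity, read by MTT assay, with a stated time of 48 h; on this read-out higher numbers stand for weaker inhibition and lower numbers for stronger inhibition:
Compound 1 `COc1ccc(-c2nc3cnccc3n2-c2cc(OC)c(OC)c(OC)c2)cc1O` gives > 20000 nM (a limit)
Compound 2 `COc1ccc(-c2cc3c(cn2)[nH]c(=O)n3-c2cc(OC)c(OC)c(OC)c2)cc1O` gives 490 nM
Compound 3 `COc1ccc(-n2c(=O)[nH]c3cnc(-c4cc(OC)c(OC)c(OC)c4)cc32)cc1O` gives > 20000 nM (a limit)

For the measured compounds named here, only one of these three readings is an actual number. Compound 1 gives > 20000 nM, which is a limit. Compound 3 gives > 20000 nM, which is also a limit. Going by the values given here, compound 2 gives 490 nM, the only number in this assay. The other readings in the series stand at the limit of > 20000 nM in this assay, at which 2 of the 3 values shown sit.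

Compound 4 `COc1ccc(-c2cc3c(cn2)[nH]c(=O)n3-c2cc(OC)c(OC)c(OC)c2)cc1C(=O)O` keeps the core of compound 2 and alters a single group: carboxy in place of hydroxy on an aromatic carbon. In words, carboxy takes the place of hydroxy on an aromatic carbon, ortho to a methoxy group and meta to a large group, so that 3-hydroxy-4-methoxyphenyl becomes 3-carboxy-4-methoxyphenyl.

Among the compounds with values here, no measured pair isolates this change. The expectation therefore starts from compound 2 at 490 nM and is uncertain. A move towards weaker inhibition, clearly beyond the scatter, is expected in this assay, and a reading at the limit would be no surprise. The estimated change is a 12-fold higher number from compound 2 to compound 4 (1.09 log units; beyond the scatter). For compound 4 the expected value is 6000 nM, within an estimated range of 1200 nM to 20000 nM.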

Compound 4, half-maximal inhibitory concentration: 5990 nM
Beside the measured number, compound 4's estimate is 1.0-fold (0.00 log units) above it; the range from low to high includes it.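

The series now holds its first pair of compounds that differ in one place, and in this assay the change from hydroxy to carboxy on this aromatic carbon, ortho to a methoxy group, gives a 12-fold higher number from compound 2 to compound 4 (1.09 log units; beyond the scatter). The position is therefore sensitive to what it carries, even though the two groups have the same count of hydrogen-bond donors and acceptors and differ in heavy atoms, with 3 in carboxy against 1 in hydroxy. The weakening is large but not complete, as compound 4 still gives an actual number and not a limit: the limit of > 20000 nM in this assay, at which 2 of the 4 values shown sit.

With only hydroxy and carboxy shown at this carbon, the compounds leave open whether the weaker inhibition follows from the loss of hydroxy, from the added carbonyl or from the greater number of heavy atoms. A methyl ester, a primary amide, an amine or a fluorine at the same carbon would help to tell these readings apart, and each could be set against compound 2 and compound 4.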